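A few compounds are considered here, and "the series" means these few. Any claim that something is new, unique, unknown or untested is made for them only; others in the source may bear on it.

Measured so far:
compound 1 `CC(C)(C)OC(=O)N1CCC(O[C@H]2CC[C@H](Oc3ccc(C#N)cc3)CC2)CC1`: 45 nM
compound 2 `CC(C)OC(=O)N1CCC(O[C@H]2CC[C@H](Oc3ccc(S(C)(=O)=O)nc3)CC2)CC1`: 201 nM
compound 3 `CC1(OC(=O)N2CCC(O[C@H]3CC[C@H](Oc4cnc(S(C)(=O)=O)cn4)CC3)CC2)CC1`: 138 nM

All three were tested in a functional assay on isolated protein for agonist activity at Glucose-dependent insulinotropic receptor (Rattus norvegicus), read by HTRF and cAMP accumulation; a higher number here means that more compound is needed for the effect, a lower number that less compound is needed. Compound 3, at 138 nM, has the second highest number of the three. Its nearest neighbour is compound 2, whose number differs from it by an amount within the usual scatter, so the two cannot be told apart. Compound 1 lies further off, with a number beyond the scatter below that of compound 3.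

Compound 4 `CC(F)Cc1nc(CN2CCC(O[C@H]3CC[C@H](Oc4cnc(S(C)(=O)=O)cn4)CC3)CC2)no1` has not yet been measured. It differs from compound 3 in one place:
(5-(2-fluoropropyl)-1,2,4-oxadiazol-3-yl)methyl in place of ((1-methylcyclopropyl)oxy)carbonyl on an amine nitrogen in a ring
The rest of the shared core is unchanged. Among the compounds with values here, no measured pair shows this kind of exchange, so there is no step to lean on; across compounds 1 to 3 the group on the ring nitrogen changes only in small ways and the numbers stay in a narrow band, whereas this exchange is larger. The step from compound 3 to compound 4 is expected to be a 1.6-fold higher number from compound 3 to compound 4 (0.20 log units; within the scatter), a modest move toward a higher number, with wide uncertainty. For compound 4 the estimate in this assay is 220 nM, within a range from 50 nM to 900 nM.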

Compound 4, half-maximal effective concentration: 267 nM
For compound 4 the middle estimate is 1.2-fold (0.08 log units) below the measured one, within the range that was stated.
By their numbers in this assay, from the lowest: compound 1; then compounds 3, 2 and 4 (each within the scatter of the next).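

In this assay, the exchange on an amine nitrogen in a ring gives a 1.9-fold higher number from compound 3 to compound 4 (0.29 log units; within the scatter), so compound 3 and compound 4 cannot be told apart despite the size of the swap. Compounds 1 to 3 all carry an oxycarbonyl group at this position, so compound 4 adds something new: a (5-(2-fluoropropyl)-1,2,4-oxadiazol-3-yl)methyl group, which has no carbonyl and brings a five-membered aromatic ring with 3 hetero atoms, still gives a number in the same range as compound 3. Within the data shown here, nothing measured here accounts for this result, so the data show only that the exchange is tolerated in this assay, not how.

The new group differs from the old one in several features at once, so the compounds shown cannot separate what the aromatic ring, the methyl link and the fluorine each contribute. From the compounds shown here alone, it remains open whether a plain propyl chain in place of the 2-fluoropropyl part, or a simple benzyl group on the same nitrogen, would keep the number within the scatter of compound 3.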